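The source may report more compounds than this note shows. Statements on the series, on what has been measured and on what is new or still open speak of the compounds shown alone.

Working notes on the series, read in a physicochemical assay for lipophilicity, read by HPLC, at pH 7.4; a lower number here means a more polar compound, a higher number a more lipophilic compound. Among the measured compounds shown here, compound 1 `Cc1cc(OCCCN2CCCC2=O)cc(C)c1-c1cccc(COc2ccc3c(c2)OC[C@H]3CC(=O)O)c1` gives 3.22 and compound 2 `Cc1nc(C)c(COc2cc(C)c(-c3cccc(COc4ccc5c(c4)OC[C@H]5CC(=O)O)c3)c(C)c2)s1` gives 4.27, so compound 2 holds the higher of the two numbers so far. For the measured compounds named here, the one measured step is a number 1.05 log units higher from compound 1 to compound 2 (beyond the scatter), with 2,4-dimethyl-1,3-thiazol-5-yl in place of 2-(2-oxopyrrolidin-1-yl)ethyl on a saturated chain carbon bound to an oxygen on an aromatic ring.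

Compound 3 `CCS(=O)(=O)CCOc1cc(C)c(-c2cccc(COc3ccc4c(c3)OC[C@H]4CC(=O)O)c2)c(C)c1` changes the same place: (ethylsulfonyl)methyl in place of 2,4-dimethyl-1,3-thiazol-5-yl on a saturated chain carbon bound to an oxygen on an aromatic ring. The 2,4-dimethyl-1,3-thiazol-5-yl leaves again, this time for (ethylsulfonyl)methyl. Going by the values given here, no measured compound carries this group, so only one step bears on the change, and it is read in reverse. Among the compounds with values here, compound 1, the one measured compound without 2,4-dimethyl-1,3-thiazol-5-yl, stands at 3.22, and a large move downward is therefore expected, of a size similar to a number 1.05 log units higher from compound 1 to compound 2 (beyond the scatter). The estimate is a number 0.97 log units lower from compound 2 to compound 3 (beyond the scatter). For compound 3 the expected value is 3.3, with an estimated range from 2.9 to 3.7.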

Compound 3, distribution coefficient: 2.73
For compound 3 the middle estimate is 0.57 log units above the measured one, and the stated range ends above it.
By their numbers in this assay, from the lowest: compound 3; then compound 1; then compound 2.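

In this assay, the new side chain shows that this position can carry the number below compound 1 as well as above it, with a number 1.54 log units lower from compound 2 to compound 3 (beyond the scatter) and a number 0.49 log units lower from compound 1 to compound 3 (beyond the scatter) as the two new readings. Compound 2 therefore stays highest and compound 3 lowest of the three, while compound 1 lies between them, so the order does not track the counts printed for the exchanged groups: 2,4-dimethyl-1,3-thiazol-5-yl and (ethylsulfonyl)methyl carry the same numbers of hydrogen-bond donors and acceptors, yet the step between them is large and beyond the scatter. No supporting measurement is available to explain this order.

The three compounds leave open whether the low number belongs to the sulfonyl group itself or to the open chain that carries it, since the exchange from compound 2 to compound 3 replaces an aromatic ring and introduces the sulfonyl group in one step. A sulfonamide or a longer chain ending in the same ethylsulfonyl group, or a terminal amine or carboxylic acid in this place, would test how far the number can move from compound 3.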